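This account rests on a few compounds, and the source may have more. Where it says the series, first, only, none or still open, it means among the compounds named here.

In an ADME assay on HepG2 cells (Homo sapiens) for cytotoxicity, read by MTT assay, with a stated time of 72 h (on this read-out higher numbers stand for lower toxicity in this test and lower numbers for higher toxicity in this test), each measured compound gives a limit, not a number:

Compound 1 `CS(=O)(=O)Cc1nc2c(Br)cc(Cl)cn2c1N`: > 125000 nM
Compound 2 `Cc1nc2c(Sc3ccc(Cl)cc3)cc(Cl)cn2c1[N+](=O)[O-]`: > 7800 nM
Compound 3 `O=[N+]([O-])c1c(CS(=O)(=O)c2ccccc2)nc2c([Se]c3ccc(Cl)cc3)cc(Cl)cn12`: > 7800 nM

Compound 2 therefore has no exact value and stands at the limit of > 7800 nM in this assay, at which 2 of the 3 values shown sit. Compound 4 `O=[N+]([O-])c1c(CS(=O)(=O)C2CCCCC2)nc2c(Sc3ccc(Cl)cc3)cc(Cl)cn12` differs from compound 2 by one change: cyclohexylsulfonyl in place of hydrogen on a saturated chain carbon bound to an aromatic carbon. Compound 3 also carries a sulfonyl group, and its result is likewise a limit, > 7800 nM. For the measured compounds named here, no measured step shows what this change does, so no shift beyond the usual scatter is expected in this assay, and another limit is quite possible. The expected size of the change is a step that the limit leaves unreadable from compound 2 to compound 4. Compound 4 is estimated at 10000 nM, with an expected range of 4500 nM to 25000 nM.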

Compound 4, half-maximal cytotoxic concentration: > 31200 nM
Compound 4 gave a limit, no number (the forecaster's own chance of this, stated with the estimate: 65%); at least 3.1-fold (0.49 log units) between middle value and limit.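

Compound 2 and compound 4 both gave limits rather than numbers, so the step between them cannot be read. The compounds shown leave open whether cyclohexylsulfonyl in place of hydrogen changes toxicity to these cells at all.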